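This account rests on a few compounds, and the source may have more. Where it says the series, first, only, none or still open, it means among the compounds named here.

Three compounds of one series, all with the same core, have been measured in an ADME assay on L6 cells (Rattus norvegicus) for cytotoxicity, read by resazurin assay, with a stated time of 70 h; a lower number here means a stronger inhibitor, a higher number a weaker inhibitor. Compound 1 `N=C(N)c1ccc2cc(-c3ccc(OCCCCOc4ccccc4)cc3)oc2c1` gives 14100 nM. Compound 2 `CC(C)NC(=N)c1ccc2cc(-c3ccc(OCCCCOc4ccccc4)cc3)oc2c1` gives 15900 nM, and compound 3 `c1ccc(OCCCCOc2ccc(-c3cc4ccc(C5=NCCN5)cc4o3)cc2)cc1` gives 16900 nM. Compound 3 stands at the highest of the three numbers, yet the steps of a 1.2-fold higher number from compound 1 to compound 3 (0.08 log units; within the scatter) and a 1.1-fold higher number from compound 2 to compound 3 (0.03 log units; within the scatter) both sit within the scatter, as does a 1.1-fold higher number from compound 1 to compound 2 (0.05 log units; within the scatter), so the three compounds are not separated in this assay.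

Compound 4 `c1ccc(OCCCCCOc2ccc(-c3cc4ccc(C5=NCCN5)cc4o3)cc2)cc1` differs from compound 3 by phenoxymethyl in place of phenoxy on a saturated chain carbon, four bonds along the chain from an oxygen on an aromatic ring. For the measured compounds named here, none of the measured steps touches the linker chain; all three vary the amidine end and all are flat. Nothing therefore points to a step beyond the scatter, in either direction, and compound 4 is expected to come out close to compound 3, with a 1.0-fold higher number from compound 3 to compound 4 (0.00 log units; within the scatter). The estimate for compound 4 in this assay is 17000 nM, within a range of 8000 nM to 36000 nM.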

Compound 4, half-maximal inhibitory concentration: 3200 nM
The estimate for compound 4 lay 5.3-fold (0.73 log units) above the measured number; the whole stated range lies above it.
By their numbers in this assay, from the lowest: compound 4; then compounds 1, 2 and 3 (each within the scatter of the next).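

For the compounds shown here, on the saturated chain, four bonds along from an oxygen on an aromatic ring, this assay responds where the amidine end did not: phenoxymethyl in place of phenoxy gives a 5.3-fold lower number from compound 3 to compound 4 (0.72 log units; beyond the scatter) and is the first step beyond the scatter. The linker chain is therefore a position that can move this number, though only this one change on it is shown. Nothing measured here accounts for the step.

On these data alone, whether a longer chain lowers the number further remains open. So does whether the same chain change carries over to the amidine ends of compound 1 and compound 2.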